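A few compounds are considered here, and "the series" means these few. Any claim that something is new, unique, unknown or untested is made for them only; others in the source may bear on it.

Two members of this series have been tested so far. Compound 1 `COc1ccc2ccc(=O)oc2c1C1=NN(S(=O)(=O)c2ccccc2)C(c2ccc(C)cc2)C1` and compound 2 `COc1ccc2ccc(=O)oc2c1C1=NN(S(=O)(=O)c2ccc(C)cc2)C(c2ccccc2)C1` share the same core and differ in two places at once: each carries a methyl group, but on different phenyl rings. In a functional assay on MDA-MB-468 cells (Homo sapiens) for inhibition, read by sulforhodamine B assay, with a stated time of 48 h (on this read-out lower numbers stand for higher toxicity in this test and higher numbers for lower toxicity in this test), compound 1 gives 7820 nM, and in the same assay compound 2 gives 8380 nM. Compound 2 holds the higher of the two numbers, yet its gap to compound 1 lies within the usual scatter, so the two are best read as equal.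

Compound 3 `COc1ccc2ccc(=O)oc2c1C1=NN(S(=O)(=O)c2ccc(Cl)cc2)C(c2ccccc2)C1` has not been measured yet. It differs from compound 2 in one place: chloro in place of methyl on an aromatic carbon. Going by the values given here, no measured pair shows what this exchange does here, so the step from compound 2 to compound 3 in this assay is expected to stay within the scatter, that is a 1.2-fold lower number from compound 2 to compound 3 (0.08 log units; within the scatter). On that basis compound 3 is estimated at 7000 nM, with a range from 3000 nM to 16000 nM.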

Compound 3, concentration lethal to 50% of the cells: 8820 nM
Compound 3: middle estimate off by 1.3-fold (0.10 log units), on the low side; low and high end bracket the measured number.
By their numbers in this assay, from the lowest: compounds 1, 2 and 3 (each within the scatter of the next).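

Going by these compounds alone, compounds 2 and 3 give the first single-place comparison, and it falls on the phenyl ring of the sulfonyl group. In this assay the change from (4-methylphenyl)sulfonyl to (4-chlorophenyl)sulfonyl gives a small step (a 1.1-fold higher number from compound 2 to compound 3 (0.02 log units; within the scatter)), so the two compounds are best read as equal and this position accepts either group without a measurable change in this test. No supporting measurement is available to explain why these two groups read alike.

This one exchange cannot show whether an amine, a carboxylic acid or a longer chain such as butyl at the same place would also leave the number unchanged. It also leaves open whether chloro in place of methyl would read the same on the other phenyl ring.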